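The source may report more compounds than this note shows. Statements on the series, on what has been measured and on what is new or still open speak of the compounds shown alone.

Working notes on the series.

The three measured compounds share the same core and differ only in the group on the thiocarbonyl carbon. In a functional assay on A-375 cells (Homo sapiens) for antiproliferative activity, read by CCK-8 assay, with a stated time of 72 h, tested at 8 uM (a lower number here means a weaker effect, a higher number a stronger effect of the compound at the concentration tested), compound 1 `Nc1ccccc1NC(=O)c1ccc(CSC(=S)N2CCc3ccccc32)cc1` gives 85.4%, compound 2 `Nc1ccccc1NC(=O)c1ccc(CSC(=S)N2CCCc3ccccc32)cc1` gives 81.5% and compound 3 `CCN(Cc1ccncc1)C(=S)SCc1ccc(C(=O)Nc2ccccc2N)cc1` gives 86.2%. Compound 1 stands second of the three, and all three lie within the scatter of one another: a number 3.9 percentage points lower from compound 1 to compound 2 (within the scatter), a number 0.8 percentage points higher from compound 1 to compound 3 (within the scatter), a number 4.7 percentage points higher from compound 2 to compound 3 (within the scatter). Exchanging one amine on the thiocarbonyl carbon for another thus leaves this assay essentially unchanged.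

Compound 4 `COC(=O)c1ccc2c(c1)CCN2C(=S)SCc1ccc(C(=O)Nc2ccccc2N)cc1` keeps the thiocarbonyl substituent of compound 1 and changes the aromatic ring of that substituent: methoxycarbonyl in place of hydrogen on an aromatic carbon. Among the compounds with values here, no measured step touches this ring, so nothing directly bears on the change. What is known is that the series has so far tolerated varied groups at the thiocarbonyl carbon without a step beyond the scatter, so a step of modest size is expected here as well, a number 3.4 percentage points lower from compound 1 to compound 4 (within the scatter). Compound 4 is therefore estimated at 82%, with a range from 66% to 93%.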

Compound 4, a percentage reported as inhibition, at one concentration (the size of the read-out at that concentration, not a potency): 79.2%
The estimate for compound 4 lay 2.8 percentage points above the measured number, and the stated range covers the measured number.
By their numbers in this assay, from the lowest: compounds 4, 2, 1 and 3 (each within the scatter of the next).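

The aromatic ring of the thiocarbonyl substituent now has a measured step of its own: in this assay, a number 6.2 percentage points lower from compound 1 to compound 4 (within the scatter) follows from methoxycarbonyl in place of hydrogen on an aromatic carbon. Within the data shown here, the tolerance seen so far at the thiocarbonyl carbon therefore extends to this one group at this one place on the substituent of compound 1, though a read-out at a single concentration gives no potency for either compound. Nothing available bears on the reason for the size of this step.

Open, as far as these compounds go, is how a carboxylic acid, an amine or a longer chain would behave on the same aromatic carbon. Also open, from the compounds shown here alone, is whether methoxycarbonyl would give a comparable step on the substituent of compound 2.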